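Fluorophenyl isomer in the cytotoxicity series

This account rests on a few compounds, and the source may have more. Where it says the series, first, only, none or still open, it means among the compounds named here.

Values in a functional assay on A-375 cells (Homo sapiens) for cytotoxicity, read by CCK-8 assay, with a stated time of 24 h (on this read-out higher numbers stand for weaker inhibition and lower numbers for stronger inhibition), follow
- compound 1 `COc1ccccc1Oc1c(N)nc(-c2ccccc2)nc1OCCO` gives > 80000 nM as a limit
- compound 2 `COc1ccccc1Oc1c(N)nc(-c2ccccc2F)nc1OCCO` gives > 80000 nM as a limit

Compound 2 stands at > 80000 nM and this is a limit of the assay, so it has no numerical value. The evidence so far is the limit of > 80000 nM in this assay, at which 2 of the 2 values shown sit, and no true number is available in the series.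

Compound 3 `COc1ccccc1Oc1c(N)nc(-c2cccc(F)c2)nc1OCCO` carries the change 3-fluorophenyl in place of 2-fluorophenyl on an aromatic carbon with 3-fluorophenyl in place of 2-fluorophenyl on an aromatic carbon. Going by the values given here, the one measured step bearing on it is a step that the two limits leave unreadable from compound 1 to compound 2 and it offers no size to carry over.

The expected step is a number no higher from compound 2 to compound 3 (the limit leaves the size open) in this assay with nothing beyond the scatter anticipated and no direction favoured. Compound 3 is estimated at 80000 nM within an expected range of 35000 nM to 160000 nM. For compound 3 a limit of the assay is also a likely outcome.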

Compound 3, half-maximal inhibitory concentration: 8530 nM
Compound 3: middle estimate off by 9.4-fold (0.97 log units), on the high side, and the stated range ends above it.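

In this assay, the position of the fluoro group on the phenyl ring decides whether a number can be read at all: 3-fluorophenyl in place of 2-fluorophenyl gives an at least 9.3-fold lower number from compound 2 to compound 3 (0.97 log units; beyond the scatter). Fluoro in place of hydrogen on an aromatic carbon, which told nothing in the 2-fluorophenyl form, now gives an at least 9.3-fold lower number from compound 1 to compound 3 (0.97 log units; beyond the scatter), so this change is not silent in every position on that ring. From the compounds shown here alone, both steps start from a limit and so stay open on one side, and the step between the two limited compounds cannot be read: the limit of > 80000 nM in this assay, at which 2 of the 3 values shown sit.

Open, going by these compounds, is whether a chloro, methoxy or nitrile group in place of the fluoro of compound 3 would also give a readable number. The compounds shown offer no reason for the difference between the two fluorophenyl isomers.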